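The source may report more compounds than this note shows. Statements on the series, on what has been measured and on what is new or still open speak of the compounds shown alone.

Values in a functional assay on MCF7 cells (Homo sapiens) for antiproliferative activity; on this read-out lower numbers stand for stronger inhibition and higher numbers for weaker inhibition:
- compound 1 `CC(C)=CCc1cc(C(=O)Nc2cc3ccc(OCC4CCCNC4)c(C)c3oc2=O)ccc1O`: 790 nM
- compound 2 `CCN(C)CCCOc1ccc2cc(NC(=O)c3ccc(O)c(CC=C(C)C)c3)c(=O)oc2c1C`: 2190 nM

Of the two measured compounds, compound 2 has the higher number, 2190 nM. Compound 3 `CC(C)=CCc1cc(C(=O)Nc2cc3ccc(OCCCNCC(C)C)c(C)c3oc2=O)ccc1O` departs from it by isobutylamino in place of ethyl(methyl)amino on a saturated chain carbon, three bonds along the chain from an oxygen on an aromatic ring, with isobutylamino in place of ethyl(methyl)amino on a saturated chain carbon, three bonds along the chain from an oxygen on an aromatic ring. Going by the values given here, only one measured step bears on this change: a 2.8-fold higher number from compound 1 to compound 2 (0.44 log units; beyond the scatter). It is modest and replaces piperidin-3-yl with 2-(ethyl(methyl)amino)ethyl on the same chain carbon bound to the oxygen. Among the compounds with values here, no measured step covers isobutylamino itself, so the guide is thin. A step of similar or smaller size towards a lower number in this assay is expected, and it may not clear the scatter. The expected change is a 1.7-fold lower number from compound 2 to compound 3 (0.23 log units; within the scatter). For compound 3 the estimated value is 1300 nM, with an expected range of 500 nM to 3300 nM.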

Compound 3, half-maximal inhibitory concentration: 1320 nM
Beside the measured number, compound 3's estimate is 1.0-fold (0.01 log units) below it, within the range that was stated.
By their numbers in this assay, from the lowest: compounds 1, 3 and 2 (each within the scatter of the next, the first and the last beyond it).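

In this assay, isobutylamino in place of ethyl(methyl)amino at this chain carbon gives a 1.7-fold lower number from compound 2 to compound 3 (0.22 log units; within the scatter) and so is not resolved as a real shift, even though the entering group carries a hydrogen-bond donor that the leaving group lacks. The open-chain 2-(isobutylamino)ethyl against the piperidin-3-yl gives a 1.7-fold higher number from compound 1 to compound 3 (0.22 log units; within the scatter) and thus, unlike a 2.8-fold higher number from compound 1 to compound 2 (0.44 log units; beyond the scatter) with its change beyond the scatter, shows no separation from the ring-bearing side chain, leaving compound 3 unresolved from both neighbours. No evidence on the origin of these values is available.

Open, on these data alone, is whether a primary amine, a morpholine or a longer chain at this position would give a number clearly apart from these three. Also open, as far as these compounds go, is whether any such change would hold in a second assay.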